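Series notes: aryloxy variation on the shared core

This account rests on a few compounds, and the source may have more. Where it says the series, first, only, none or still open, it means among the compounds named here.

Measured compounds in an assay on isolated protein for agonist activity at Bile acid receptor (Homo sapiens), read by AlphaScreen, with a stated time of 30 min; on this read-out higher numbers stand for an effect only at larger amounts of compound and lower numbers for an effect already at smaller amounts:
compound 1 `COc1ccc(C2SC(C)C(=O)Nc3c2c(C)nn3-c2ccccc2C)c(OC)c1` gives 10500 nM
compound 2 `COc1ccc(Oc2ccc([C@H]3S[C@@H](C)C(=O)Nc4c3c(C)nn4-c3ccccc3C)cc2)cc1` gives 2200 nM
compound 3 `Cc1nn(-c2ccccc2C(C)C)c2c1[C@@H](c1ccc(Oc3ccccc3)cc1)S[C@@H](C)C(=O)N2` gives 1900 nM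

Compound 2 holds the second highest of the three numbers in this assay. Its nearest neighbour is compound 3, whose number is lower by a margin that lies within the scatter, so the two values cannot be told apart. Compound 1, which carries no aryloxy substituent on the pendant ring, stands furthest away with a number beyond the scatter above compound 2; this is the only gap among the three that counts as a real difference.

Compound 4 `Cc1ccccc1-n1nc(C)c2c1NC(=O)[C@H](C)S[C@@H]2c1ccc(Oc2ccccc2C(=O)O)cc1` is the next member to be tested. It differs from compound 2 in one place:

2-carboxyphenyl in place of 4-methoxyphenyl on an oxygen on an aromatic ring

Among the compounds with values here, no pair of measured compounds shows this particular change, so its effect must be guessed. What the measured values do show is that the aryloxy-bearing compounds 2 and 3 sit well below compound 1, and that the substituent on the outer ring of that aryloxy group made no visible difference between compounds 2 and 3. Introducing a carboxylic acid is a larger departure than the methoxy-to-hydrogen contrast between those two. Compound 4 is expected to give a somewhat lower number, with a step of about a 1.8-fold lower number from compound 2 to compound 4 (0.26 log units; within the scatter), though a result within the scatter of compound 2 would not be surprising. The estimate for compound 4 is 1200 nM, in the range 300 nM to 5000 nM.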

Compound 4, half-maximal effective concentration: "not active" (no number reported)
No number was reported for compound 4, and the estimate cannot be compared.
By their numbers in this assay, from the lowest: compounds 3 and 2 (each within the scatter of the next); then compound 1.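

In this assay, within the data shown here, compound 4 is reported as not active, with no number, so no step from compound 2 to compound 4 can be read. Nothing shown here bears on the reason for this result. The compounds shown leave open whether the 2-carboxyphenyl group itself or its substitution pattern decides this outcome.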